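The compounds below may be only part of what the source reports. "The series", "measured", "known", "first", "only" and "open" are said of these compounds alone.

In a functional assay on blood (Homo sapiens) for inhibition (a higher number here means a weaker inhibitor, a lower number a stronger inhibitor), compound 3 `c1ccc(C2(c3cc(OCc4ccccn4)ccc3OCc3ccccn3)CC3CCC2C3)cc1` gives 275 nM, while compound 2 `Oc1ccc(OCc2ccc3ccccc3n2)cc1C1(c2ccccc2)CC2CCC1C2` gives 580 nM, a gap beyond the usual scatter. Compound 1 `O=C(Nc1cccnc1)Oc1ccc(OCc2nc3ccccc3s2)cc1C1(c2ccccc2)CC2CCC1C2` gives 37 nM; 86 nM; 33 nM (3 entries), several entries that all lie lower than the numbers of the other two. Compound 4 `c1ccc(C2(c3cc(OCc4ccc5occc5n4)ccc3OCc3ccccn3)CC3CCC2C3)cc1` differs from compound 3 in one place: a group of 9 heavy atoms (7 carbon, 1 nitrogen, 1 oxygen; one five-membered aromatic ring with 1 hetero atom, one six-membered aromatic ring with 1 hetero atom) in place of a group of 6 heavy atoms (5 carbon, 1 nitrogen; one six-membered aromatic ring with 1 hetero atom), on a saturated chain carbon bound to an oxygen on an aromatic ring. For the measured compounds named here, no measured pair isolates such a change, so any expectation here is loose. The pull is mixed, with compound 1 lower at 37 nM; 86 nM; 33 nM (3 entries) and compound 2 higher at 580 nM. In this assay a modest drop is expected, and the estimated size is a 2.1-fold lower number from compound 3 to compound 4 (0.33 log units; beyond the scatter). For compound 4 the expected value is 130 nM, with an estimated range of 40 nM to 420 nM.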

Compound 4, half-maximal inhibitory concentration: 80 nM
Beside the measured number, compound 4's estimate is 1.6-fold (0.21 log units) above it; the measured number falls inside the stated range.
By their numbers in this assay, from the lowest: compound 4; then compound 3; then compound 2.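

In this assay replacing pyridin-2-yl with the larger two-ring group gives a 3.4-fold lower number from compound 3 to compound 4 (0.54 log units; beyond the scatter) and so shows that this place, a saturated chain carbon bound to an oxygen on an aromatic ring, tolerates the bigger group and even gains from it. For the compounds shown here, this is the first measured pair that isolates a change at this place. Nothing among the data explains why the two-ring group gives the lower number. Still open, from the compounds shown here alone, is whether the ring oxygen of the entering group matters, and how a plain phenyl ring or a morpholine would behave on the same carbon.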